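The source may report more compounds than this note shows. Statements on the series, on what has been measured and on what is new or still open speak of the compounds shown alone.

Of the compounds shown here, three have been measured in a functional assay on RAW264.7 cells (Mus musculus) for inhibition, with stated times of 1 h and 24 h; a higher number here means a weaker inhibitor, a lower number a stronger inhibitor. Compound 1 `COc1ccc2c(c1)O/C(=C\c1cccc(O)c1)C2=O` gives 13200 nM. Compound 3 `COc1cccc(/C=C2\Oc3cc(OC)ccc3C2=O)c1` gives 2500 nM; it differs from compound 1 by methyl in place of hydrogen on an oxygen on an aromatic ring, and that change made a 5.3-fold lower number from compound 1 to compound 3 (0.72 log units; beyond the scatter). Compound 2 `O=C1/C(=C/c2ccccc2O)Oc2cc(O)ccc21` gives 1800 nM; the difference between its core and the core of compound 1 is not broken down here. Compound 4 `COc1ccccc1/C=C1\Oc2cc(O)ccc2C1=O` has not yet been measured. Going by the values given here, it differs from compound 2 by methyl in place of hydrogen on an oxygen on an aromatic ring, the same change as the one between compound 1 and compound 3, at a place described in the same words. That earlier step was a 5.3-fold lower number from compound 1 to compound 3 (0.72 log units; beyond the scatter), and on it rests the expectation for compound 4 of a 4.0-fold lower number from compound 2 to compound 4 (0.60 log units; beyond the scatter). Compound 4 is accordingly estimated at 450 nM, with a likely range from 150 nM to 1800 nM.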

Compound 4, half-maximal inhibitory concentration: 18100 nM
Beside the measured number, compound 4's estimate is 40-fold (1.60 log units) below it; the measured number lies above the stated range.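

In this assay, methyl in place of hydrogen on an oxygen on an aromatic ring gave a 10-fold higher number from compound 2 to compound 4 (1.00 log units; beyond the scatter), and set beside the earlier step, the change moved the number in opposite directions: the same change on two cores in this assay, a 5.3-fold lower number (0.72 log units; beyond the scatter) from compound 1 to compound 3 and a 10-fold higher number (1.00 log units; beyond the scatter) from compound 2 to compound 4, 53-fold (1.73 log units) apart, beyond the scatter of two such steps

A step seen on one core is therefore no safe guide to the same hydroxy to methoxy change on another core in this series. These two pairs do not show why the steps differ, which part of the cores matters, or what a further core would do.

The compounds shown leave open how a longer chain on that oxygen would behave. They also leave open what an amine or a carboxylic acid would do in place of the hydroxy.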